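A few compounds are considered here, and "the series" means these few. Any claim that something is new, unique, unknown or untested is made for them only; others in the source may bear on it.

Measured so far in a functional assay (aorta) with Rattus norvegicus as the target; a lower number here means a stronger inhibitor, a higher number a weaker inhibitor:
compound 1 `CCO/C(O)=C1\C(COCCn2c(C)nc(C)c2C)=NC(C)=C(C(=O)OC)C1c1ccccc1Cl`: 5.01 nM
compound 2 `CCO/C(O)=C1\C(COCCn2nncc2C(N)=O)=NC(C)=C(C(=O)OC)C1c1ccccc1Cl`: 100 nM
compound 3 `CCO/C(O)=C1\C(COCCN2CC(=O)N=C2N)=NC(C)=C(C(=O)OC)C1c1ccccc1Cl`: 20 nM

Compound 1 gives the lowest number of the three; compound 3 is nearest a 4.0-fold higher number from compound 1 to compound 3 (0.60 log units; beyond the scatter) and compound 2 furthest a 20-fold higher number from compound 1 to compound 2 (1.30 log units; beyond the scatter). Compound 4 `CCO/C(O)=C1\C(COCCn2cc(N)nc2O)=NC(C)=C(C(=O)OC)C1c1ccccc1Cl` is not yet measured; it differs from compound 1 at the same position as compounds 2 and 3: 4-amino-2-hydroxy-1H-imidazol-1-yl in place of 2,4,5-trimethyl-1H-imidazol-1-yl on a saturated chain carbon, two bonds along the chain from an oxygen on a saturated carbon. Both measured steps from compound 1 replace the 2,4,5-trimethyl-1H-imidazol-1-yl with a group carrying hydrogen-bond donors, and both raise the number in this assay, one modestly and one largely. A higher number is therefore expected for compound 4, an 8.0-fold higher number from compound 1 to compound 4 (0.90 log units; beyond the scatter), a step estimated between those two because of a 4.0-fold higher number from compound 1 to compound 3 (0.60 log units; beyond the scatter) and a 20-fold higher number from compound 1 to compound 2 (1.30 log units; beyond the scatter). Compound 4 is expected to give about 40 nM in this assay, within 10 nM to 160 nM.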

Compound 4, half-maximal inhibitory concentration: 31.6 nM
Beside the measured number, compound 4's estimate is 1.3-fold (0.10 log units) above it; measured number inside the range.
By their numbers in this assay, from the lowest: compound 1; then compounds 3 and 4 (each within the scatter of the next); then compound 2.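

In this assay the aromatic ring with 2 hetero atoms is kept in 4-amino-2-hydroxy-1H-imidazol-1-yl, yet the number does not stay with compound 1 (a 6.3-fold higher number from compound 1 to compound 4 (0.80 log units; beyond the scatter)). A ring of this kind and the non-aromatic group of the same heavy-atom count are not separated (a 1.6-fold higher number from compound 3 to compound 4 (0.20 log units; within the scatter)), while 5-carbamoyl-1H-1,2,3-triazol-1-yl stays apart (a 3.2-fold lower number from compound 2 to compound 4 (0.50 log units; beyond the scatter)). No evidence in hand bears on these steps.

Compound 4 changes the methyl groups and adds the amino and hydroxy groups at once, so their shares cannot be separated. On these data alone, an unsubstituted imidazol-1-yl on the same 2-ethoxy chain would address this, and a longer chain remains open.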